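Methoxy removal on the aryl ketone of compound 2

A few compounds are considered here, and "the series" means these few. Any claim that something is new, unique, unknown or untested is made for them only; others in the source may bear on it.

Going by the values given here, compound 2 `COc1ccc(C(=O)/C=C/c2cc(-c3cc(OC)c(OC)c(OC)c3)n[nH]2)cc1OC` gives 101% in a functional assay on HOP-62 cells (Homo sapiens) for cytotoxicity, read by sulforhodamine B assay, with a stated time of 48 h, tested at 0.01 uM (on this read-out lower numbers stand for a stronger effect and higher numbers for a weaker effect at the one concentration tested), the higher of the two numbers known. Among the compounds with values here, compound 1 `COc1cc(-c2cc(/C=C/C(=O)c3ccc(N)cc3)[nH]n2)cc(OC)c1OC` gives 83% in this assay; the only measured step, a number 18 percentage points higher from compound 1 to compound 2 (beyond the scatter), concerns the group on the carbonyl carbon and does not bear directly on the present change. Compound 3 `COc1ccc(C(=O)/C=C/c2cc(-c3cc(OC)c(OC)c(OC)c3)n[nH]2)cc1` differs from compound 2 by hydrogen in place of methoxy on an aromatic carbon. Within the data shown here, with no step of this kind measured, the change from compound 2 to compound 3 is expected to stay within the scatter, a number 3 percentage points lower from compound 2 to compound 3 (within the scatter). Compound 3 is therefore estimated at 98%, within 85% to 110%.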

Compound 3, a percentage reported as activity, at one concentration (the size of the read-out at that concentration, not a potency): 99%
Compound 3: the middle estimate sits 1 percentage points below what was measured; measured number inside the range.
By their numbers in this assay, from the lowest: compound 1; then compounds 3 and 2 (each within the scatter of the next).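

In this assay the change from 3,4-dimethoxyphenyl to 4-methoxyphenyl reads as a number 2 percentage points lower from compound 2 to compound 3 (within the scatter) and so leaves the number unmoved at this position, with hydrogen and methoxy not told apart. Going by these compounds alone, on the same ring, methoxy in place of amino on an aromatic carbon gives a number 16 percentage points higher from compound 1 to compound 3 (beyond the scatter) and a weaker effect, so the amino group of compound 1 marks the one change here that exceeds the scatter. Nothing available explains either step.

Going by these compounds, whether a hydroxyl or an amine at the position of the removed methoxy would shift the number remains open. So does whether compound 2 and compound 3 separate at higher concentrations.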